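From 3,4-Dichlorophenyl to 2,4-Dichlorophenyl: An Expected Outcome

A few compounds are considered here, and "the series" means these few. Any claim that something is new, unique, unknown or untested is made for them only; others in the source may bear on it.

Compound 1 `CNC(=O)c1cc(Oc2ccc(C(=O)/C=C/c3ccc(Cl)c(Cl)c3)cc2)ccn1`: 13200 nM
Compound 2 `CNC(=O)c1cc(Oc2ccc(C(=O)/C=C/c3ccc([N+](=O)[O-])cc3)cc2)ccn1`: "not determined" (no result reported)
Compound 3 `CNC(=O)c1cc(Oc2ccc(C(=O)/C=C/c3ccc(OC)cc3)cc2)ccn1`: "not determined" (no result reported)

For the measured compounds named here, in a functional assay on MCF7 cells (Homo sapiens) for cytotoxicity, read by MTT assay, with a stated time of 72 h (on this read-out higher numbers stand for weaker inhibition and lower numbers for stronger inhibition), compound 1 gives 13200 nM, the only number in this set; compound 2 and compound 3 share the same core but carry no reported value, so compound 1 cannot be ranked against anything. Compound 4 `CNC(=O)c1cc(Oc2ccc(C(=O)/C=C/c3ccc(Cl)cc3Cl)cc2)ccn1` is not yet measured. It differs from compound 1 by 2,4-dichlorophenyl in place of 3,4-dichlorophenyl on a double-bonded chain carbon bound to a double-bonded chain carbon. Going by the values given here, no step between measured compounds exists to suggest how this assay responds to such a change. The author therefore expects the step of a 1.0-fold lower number from compound 1 to compound 4 (0.01 log units; within the scatter) to stay within the usual scatter, in no clear direction. Compound 4 is estimated at 13000 nM, with a range from 5000 nM to 35000 nM.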

Compound 4, half-maximal inhibitory concentration: 3990 nM
Compound 4: the middle estimate sits 3.3-fold (0.51 log units) above what was measured, and the stated range ends above it.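

In this assay, for the compounds shown here, 2,4-dichlorophenyl in place of 3,4-dichlorophenyl gives a 3.3-fold lower number from compound 1 to compound 4 (0.52 log units; beyond the scatter), the only readable step in this set. It shows that this position responds to where the two chlorines sit, even though the two compounds have the same atoms. Nothing at hand explains the shift.

Steps involving compound 2 and compound 3 cannot be read, as neither has a value. From the compounds shown here alone, whether a phenyl group carrying fluorine or trifluoromethyl at this position would give a lower or higher number remains open.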